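The source may hold more compounds than are shown below. What is called first, only, known or untested is meant among the compounds shown, and "the series" means these compounds.

In a functional assay on SW480 cells (Homo sapiens) for cytotoxicity, read by sulforhodamine B assay, with a stated time of 48 h (on this read-out lower numbers stand for stronger inhibition and higher numbers for weaker inhibition), compound 1 `COc1cc(/C=C/C(=O)c2ccc(N)c(-c3ccc(F)cc3)c2)cc(Br)c1O` gives 22900 nM, and compound 3 `COc1ccc(-c2cc(C(=O)/C=C/c3cc(OC)c(OC)c(OC)c3)ccc2N)cc1OC` gives 5630 nM. Going by the values given here, these two values are the only numbers available, and neither compound is a close neighbour of the pair at issue here. For compound 2 `COc1ccc(/C=C/C(=O)c2cccc(-c3cccc(F)c3)c2)cc1O` the result reads "not determined" (no result reported), so it has no position on this scale and offers no starting value. Its close relative, compound 4 `COc1ccc(/C=C/C(=O)c2cccc(-c3cccc(F)c3)c2)cc1`, has not yet been measured. The structural change is small: hydrogen in place of hydroxy on an aromatic carbon. Hydrogen stands in place of hydroxy on an aromatic carbon, ortho to a methoxy group and meta to a large group. Among the compounds with values here, no measured pair shows what this exchange does in this assay, so any expectation is tentative. No step beyond the usual scatter is expected from it, in either direction, and the best guide is the general level set by compound 1 and compound 3. Compound 4 is estimated at 18000 nM, with an expected range of 5500 nM to 60000 nM.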

Compound 4, half-maximal inhibitory concentration: 4510 nM
For compound 4 the middle estimate is 4.0-fold (0.60 log units) above the measured one; measured number below the stated range.
By their numbers in this assay, from the lowest: compounds 4 and 3 (each within the scatter of the next); then compound 1.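

In this assay compound 4 gives 4510 nM but no step can be read to it from compound 2, whose entry holds no number. The compounds shown leave open what hydrogen in place of hydroxy does here. No evidence on hand bears on this result.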